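Chloro for methyl, carried from one core to the other

The compounds below may be only part of what the source reports. "The series", "measured", "known", "first", "only" and "open" are said of these compounds alone.

Compound 1 `Cc1cc(-n2cc(C(=O)Nc3cc(F)cc(F)c3)c(=O)c3ccc(N(C)C)nc32)ccc1OCCCCCCC[n+]1ccccc1` and compound 2 `CN(C)c1ccc2c(=O)c(C(=O)Nc3cc(F)cc(F)c3)cn(-c3ccc(OCCCCCCC[n+]4ccccc4)c(Cl)c3)c2n1` share a core and differ in one place: chloro in place of methyl on an aromatic carbon. In an assay on LX2 cells for inhibition of COL1A1 promoter (Homo sapiens), read by a luciferase reporter, with a stated time of 24 h, tested at 50 uM (on this read-out lower numbers stand for a weaker effect and higher numbers for a stronger effect at the one concentration tested), compound 1 gives 55% and compound 2 gives 21.4%, so that the change gave a number 33.6 percentage points lower from compound 1 to compound 2 (beyond the scatter). Compound 3 `CC[N+]1(CCCCCCCOc2ccc(-n3cc(C(=O)Nc4cc(F)cc(F)c4)c(=O)c4ccc(N(C)C)nc43)cc2C)CCCCC1` differs from compound 1 by a group of 8 heavy atoms (7 carbon, 1 nitrogen; one six-membered non-aromatic ring with 1 hetero atom) in place of a group of 6 heavy atoms (5 carbon, 1 nitrogen; one six-membered aromatic ring with 1 hetero atom), on a saturated chain carbon, seven bonds along the chain from an oxygen on an aromatic ring; in this assay compound 3 gives 53.4%, and the core change gave a number 1.6 percentage points lower from compound 1 to compound 3 (within the scatter). Compound 4 `CC[N+]1(CCCCCCCOc2ccc(-n3cc(C(=O)Nc4cc(F)cc(F)c4)c(=O)c4ccc(N(C)C)nc43)cc2Cl)CCCCC1` is not yet measured; it differs from compound 3 by chloro in place of methyl on an aromatic carbon, the same change as from compound 1 to compound 2, at the same place. Because the change gave a number 33.6 percentage points lower from compound 1 to compound 2 (beyond the scatter), and because the core change gave a number 1.6 percentage points lower from compound 1 to compound 3 (within the scatter), a step of about the same size is expected for compound 4 a number 32.4 percentage points lower from compound 3 to compound 4 (beyond the scatter). Compound 4 is therefore estimated at 21%, with an expected range from 6% to 38%.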

Compound 4, a percentage reported as inhibition, at one concentration (the size of the read-out at that concentration, not a potency): 50.4%
The estimate for compound 4 lay 29.4 percentage points below the measured number; measured number outside the range, above it.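

In this assay, chloro in place of methyl did not carry from one core to the other, giving only a number 3 percentage points lower from compound 3 to compound 4 (within the scatter): the same change on two cores in this assay, a number 33.6 percentage points lower (beyond the scatter) from compound 1 to compound 2 and a number 3 percentage points lower (within the scatter) from compound 3 to compound 4, 30.6 percentage points apart, beyond the scatter of two such steps

Read the other way, exchanging the terminal six-membered aromatic ring group for the non-aromatic one gives a number 29 percentage points higher from compound 2 to compound 4 (beyond the scatter), a much larger step than in the methyl pair: the same change on two cores in this assay, a number 1.6 percentage points lower (within the scatter) from compound 1 to compound 3 and a number 29 percentage points higher (beyond the scatter) from compound 2 to compound 4, 30.6 percentage points apart, beyond the scatter of two such steps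

Across these four compounds, the result of the chloro change therefore depends on the terminal group, but a single pair of pairs at one concentration gives neither a reason for this nor a rule for other cores.

On these data alone, it remains open whether fluoro or bromo in place of methyl would follow compound 2 or compound 4. As far as these compounds go, the behaviour of a shorter chain or a trimethylammonium end group is also open.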